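Swapping the amine tail of compound 1 for a piperidine

The compounds below may be only part of what the source reports. "The series", "measured", "known", "first", "only" and "open" are said of these compounds alone.

Measured so far:
- compound 1 `CCN(CC)CCCOc1cc2ncnc(Nc3nc4ccc(C(=O)Nc5c(C)cccc5C)cc4s3)c2cc1OC` gives > 100000 nM
- compound 2 `COc1cc2c(Nc3nc4ccc(C(=O)Nc5c(C)cccc5Cl)cc4s3)ncnc2cc1OCCCN1CCC(C)CC1` gives 9100 nM
- compound 3 `CCN(CC)CCCOc1cc2ncnc(Nc3nc4ccc(C(=O)Nc5c(C)cccc5Cl)cc4s3)c2cc1OC` gives 13200 nM

All three compounds were tested in a functional assay on HCT-116 cells (Homo sapiens) for cytotoxicity, read by WST assay, with a stated time of 72 h; on this read-out lower numbers stand for stronger inhibition and higher numbers for weaker inhibition. The value of compound 1 is a limit of the assay rather than a number (the limit of > 100000 nM in this assay, at which 1 of the 3 values shown sits). Compound 3, which carries chloro in place of methyl on an aromatic carbon, gives a real number, and the change from compound 1 produced an at least 7.5-fold lower number from compound 1 to compound 3 (0.87 log units; beyond the scatter). Compound 2 and compound 3 differ only in the amine at the end of the chain, and that exchange produced a 1.5-fold higher number from compound 2 to compound 3 (0.16 log units; within the scatter).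

The unmeasured compound 4 `COc1cc2c(Nc3nc4ccc(C(=O)Nc5c(C)cccc5C)cc4s3)ncnc2cc1OCCCN1CCCCC1` differs from compound 1 in one place: piperidin-1-yl in place of diethylamino on a saturated chain carbon, three bonds along the chain from an oxygen on an aromatic ring. Of the two measured steps, only the second concerns the same position, and there an exchange of one amine for another stayed within the scatter. No step beyond the scatter is therefore expected in this assay, and compound 4 is expected to remain at the limit where compound 1 sits.

Compound 4 is estimated at 100000 nM, with a range from 40000 nM to 300000 nM. This estimate corresponds to a number no higher from compound 1 to compound 4 (the limit leaves the size open).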

Compound 4, half-maximal inhibitory concentration: > 100000 nM
Compound 4 gave a limit, no number; the forecaster's own chance of this, stated with the estimate: 70%; the middle value lies on the limit itself.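

Compound 1 and compound 4 both stand at a limit of the assay rather than at a number, so no step between them can be read: the limit of > 100000 nM in this assay, at which 2 of the 4 values shown sit.

Left open is how far apart compound 1 and compound 4 truly lie, and whether piperidin-1-yl in place of diethylamino makes any difference at all.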